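Removing a Methoxy Group from a Pyrazoline Anticonvulsant Series

The compounds below may be only part of what the source reports. "The series", "measured", "known", "first", "only" and "open" are said of these compounds alone.

The series comprises two measured compounds and one not yet tested. Compound 1 `COc1ccc(C2CC(Nc3nc4ccc(C)cc4s3)=NN2C(C)=O)cc1O` gives 73.9 umol/kg in a functional assay on the whole organism (Hindlimb, strain albino) with Mus musculus as the target, in the maximal electroshock model, with a stated time of 0.5 h; on this read-out lower numbers stand for an effect already at smaller amounts and higher numbers for an effect only at larger amounts of compound. Within the data shown here, compound 2 `COc1ccc(C2CC(Nc3nc4ccccc4s3)=NN2C(C)=O)cc1O` gives 259 umol/kg in this assay, which is the highest of the two numbers so far; its nearest neighbour is compound 1, and the only measured step, a 3.5-fold higher number from compound 1 to compound 2 (0.54 log units; beyond the scatter), is a modest change that lies beyond the scatter.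

Compound 3 `CC(=O)N1N=C(Nc2nc3ccccc3s2)CC1c1ccc(O)cc1` differs from compound 2 as follows: 4-hydroxyphenyl in place of 3-hydroxy-4-methoxyphenyl on a saturated ring carbon. Among the measured compounds shown here, this change sits on the saturated ring carbon of the shared core, a different place from the aromatic carbon altered between compound 1 and compound 2, so no measured step bears directly on it. For the measured compounds named here, with no comparable step in hand, the author expects compound 3 to fall close to compound 2 in this assay, with a step of no change at the digits printed from compound 2 to compound 3 (within the scatter) that is not expected to exceed the scatter, though the uncertainty is wide. Compound 3 is therefore estimated at 259 umol/kg, within a range from 100 umol/kg to 700 umol/kg.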

Compound 3, dose for half-maximal effect: 249 umol/kg
For compound 3 the middle estimate is 1.0-fold (0.02 log units) above the measured one, and the stated range covers the measured number.
By their numbers in this assay, from the lowest: compound 1; then compounds 3 and 2 (each within the scatter of the next).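

In this assay, among these compounds, the exchange of 3-hydroxy-4-methoxyphenyl for 4-hydroxyphenyl on the saturated ring carbon gives a 1.0-fold lower number from compound 2 to compound 3 (0.02 log units; within the scatter) and so provides the first measured step at this position, which the earlier pair did not touch. The group that enters has fewer heavy atoms and one hydrogen-bond acceptor fewer than the group that leaves, yet the number stays within the scatter, so in this compound pair the methoxy group can go and the hydroxy group can take the 4-position without a readable change in the read-out. The exchange alters both features at once, so this single step cannot show what either does alone, and a flat result could hide two opposing contributions as readily as two absent ones.

Going by these compounds, it remains open how a 3-hydroxyphenyl, a 4-methoxyphenyl or an unsubstituted phenyl would behave here, whether an amine or a carboxylic acid on this aromatic ring would be tolerated, and whether the methyl step a 3.5-fold higher number from compound 1 to compound 2 (0.54 log units; beyond the scatter) would carry over to a compound bearing 4-hydroxyphenyl. Nothing among the data given bears on why the number holds across this exchange.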